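The source may report more compounds than this note shows. Statements on the series, on what has been measured and on what is new or still open speak of the compounds shown alone.

Compound 1 `CN(C(=O)NC(=O)c1ccc(F)c(F)c1)c1nc(C(F)(F)F)c(C(=O)N/N=C/c2ccc(C(F)(F)F)cc2)s1`, compound 2 `CN(C(=O)NC(=O)c1ccc(C(F)(F)F)cc1)c1nc(C(F)(F)F)c(C(=O)N/N=C/c2ccc(C(F)(F)F)cc2)s1` and compound 3 `CN(C(=O)NC(=O)c1c(F)cccc1F)c1nc(C(F)(F)F)c(C(=O)N/N=C/c2ccc(C(F)(F)F)cc2)s1` share one core and differ only in the aryl group attached to a carbonyl carbon. In a functional assay on A549 cells (Homo sapiens) for inhibition, read by MTT assay, with a stated time of 72 h (on this read-out lower numbers stand for stronger inhibition and higher numbers for weaker inhibition), compound 1 gives 6.07 ug/mL. Compound 3 gives 40.1 ug/mL in this assay. For compound 2 the result in this assay is a limit, > 100 ug/mL, so only a range is known for it, as shown by the limit of > 100 ug/mL in this assay, at which 1 of the 3 values shown sits. The measured steps all concern that carbonyl-bound aryl: an at least 16-fold higher number from compound 1 to compound 2 (1.21 log units; beyond the scatter), a 6.6-fold higher number from compound 1 to compound 3 (0.82 log units; beyond the scatter) and an at least 2.4-fold lower number from compound 2 to compound 3 (0.39 log units; beyond the scatter). Compound 4 `CN(C(=O)NC(=O)c1ccc(C(F)(F)F)cc1)c1nc(C(F)(F)F)c(C(=O)N/N=C/c2ccccc2C(F)(F)F)s1` has not yet been measured. It differs from compound 2 in another part of the molecule: 2-(trifluoromethyl)phenyl in place of 4-(trifluoromethyl)phenyl on a carbon with a double bond to nitrogen. Going by the values given here, no measured step alters the group on the carbon with a double bond to nitrogen, so the three steps above give no direct guidance on this change. With nothing to go on beyond the standing of compound 2 at the limit of this assay, compound 4 is expected to remain weak, and the step expected in this assay is an at least 1.1-fold lower number from compound 2 to compound 4 (0.04 log units; that floor lies within the scatter). Compound 4 is therefore estimated at 90 ug/mL, within a range from 20 ug/mL to 300 ug/mL, with a fair chance that only a limit is returned again.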

Compound 4, half-maximal inhibitory concentration: 6.68 ug/mL
Compound 4: middle estimate off by 13-fold (1.13 log units), on the high side; the whole stated range lies above it.
By their numbers in this assay, from the lowest: compounds 1 and 4 (each within the scatter of the next); then compound 3. At a limit, above all of these: compound 2.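

Going by these compounds alone, changing 4-(trifluoromethyl)phenyl to 2-(trifluoromethyl)phenyl on a carbon with a double bond to nitrogen gives, in this assay, an at least 14-fold lower number from compound 2 to compound 4 (1.17 log units; beyond the scatter), so this end of the molecule also has a large influence on the read-out, which the earlier compounds, all varied only at the carbonyl-bound aryl, could not show. The two groups have the same atoms and the same counts of rings, donors and acceptors, so this large step comes from an isomeric change alone, with nothing added to or removed from the molecule. The real size of the step stays unknown, and only its lower bound can be read, because the result for compound 2 is a limit of the assay and not a number: the limit of > 100 ug/mL in this assay, at which 1 of the 4 values shown sits.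

Going by these compounds, it remains open whether a plain phenyl, or a phenyl carrying a methoxy group, an amine or a carboxylic acid in place of the trifluoromethyl group, would fit this pattern. On these data alone, it is also open whether the same change would have a similar effect on compounds carrying 3,4-difluorophenyl or 2,6-difluorophenyl on the carbonyl carbon.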